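Demethylation of the Methoxy Chalcone: Expected Cytotoxicity

The source may hold more compounds than are shown below. What is called first, only, known or untested is meant among the compounds shown, and "the series" means these compounds.

Measured compounds:
compound 1, `COc1ccc(C(=O)/C=C/c2cccc(OCc3ccccc3)c2)cc1`, 6000 nM
compound 2, `O=C(/C=C/c1cccc(OCc2ccccc2)c1)c1ccccc1`, 9800 nM

In a functional assay on MCF7 cells (Homo sapiens) for cytotoxicity, read by MTT assay, with a stated time of 68 h (on this read-out lower numbers stand for stronger inhibition and higher numbers for weaker inhibition), compound 1 gives the lowest of the two numbers; its nearest neighbour is compound 2, separated by a 1.6-fold higher number from compound 1 to compound 2 (0.21 log units; within the scatter). Compound 3, `O=C(/C=C/c1cccc(OCc2ccccc2)c1)c1ccc(O)cc1`, is not yet measured. It differs from compound 1 by hydrogen in place of methyl on an oxygen on an aromatic ring, which one bond further out reads methoxy to hydroxy. Within the data shown here, no measured step covers this exact change; the one step at hand, from compound 1 to compound 2, stayed within the scatter when the whole methoxy was removed, so compound 3 is expected to show a 1.1-fold higher number from compound 1 to compound 3 (0.03 log units; within the scatter), no shift beyond the scatter. Compound 3 is therefore estimated at 6500 nM, between 3000 nM and 14000 nM.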

Compound 3, half-maximal inhibitory concentration: 2800 nM
Estimate against measurement, compound 3: 2.3-fold (0.37 log units) above, and the stated range ends above it.
By their numbers in this assay, from the lowest: compound 3; then compounds 1 and 2 (each within the scatter of the next).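

In this assay the hydroxy on this ring does what the earlier change did not: methoxy to hydroxy gives a 2.1-fold lower number from compound 1 to compound 3 (0.33 log units; beyond the scatter) and hydroxy in place of hydrogen gives a 3.5-fold lower number from compound 2 to compound 3 (0.54 log units; beyond the scatter) on the same position. Removing the whole methoxy had stayed within the scatter, yet this position does respond, and losing only the methyl from the oxygen is enough to pass the scatter. Nothing available explains this shift. The compounds shown leave open whether an amine or a carboxylic acid on this aromatic carbon would give a number like that of the hydroxy compound.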